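Chloro in Place of Bromo on Compound 1

The compounds below may be only part of what the source reports. "The series", "measured", "known", "first", "only" and "open" are said of these compounds alone.

In a functional assay on HeLa cells (Homo sapiens) for inhibition, read by CCK-8 assay, with a stated time of 48 h (on this read-out higher numbers stand for weaker inhibition and lower numbers for stronger inhibition), compound 1 `O=C1CSC(N2N=C(c3ccc(Br)cc3)CC2c2ccc3ccccc3c2)=N1` gives 4220 nM and compound 2 `Brc1ccc(C2=NN(C3=NC(c4ccccc4)CS3)C(c3ccc4ccccc4c3)C2)cc1` gives 4960 nM as its value, so the two cannot be told apart. Compound 3 `O=C1CSC(N2N=C(c3ccc(F)cc3)CC2c2cccc3ccccc23)=N1` stands higher at 11300 nM with weaker inhibition than either. Among the measured compounds shown here, compound 4 `O=C1CSC(N2N=C(c3ccc(Cl)cc3)CC2c2ccc3ccccc3c2)=N1` carries chloro in place of bromo on an aromatic carbon and no measured step isolates that change. For the measured compounds named here, the one measured step, a 1.2-fold higher number from compound 1 to compound 2 (0.07 log units; within the scatter) and within the scatter, alters a different place. Compound 3 differs from compound 1 in more than one place, so it cannot isolate this swap either. No step beyond the scatter is therefore expected in this assay here. The estimated change is a 1.1-fold higher number from compound 1 to compound 4 (0.03 log units; within the scatter) and stays within the scatter. Compound 4 is expected at 4500 nM with a range from 2200 nM to 9000 nM in this estimate.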

Compound 4, half-maximal inhibitory concentration: 6320 nM
Compound 4: middle estimate off by 1.4-fold (0.15 log units), on the low side; low and high end bracket the measured number.
By their numbers in this assay, from the lowest: compounds 1, 2, 4 and 3 (each within the scatter of the next, the first and the last beyond it).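

In this assay, the change from 4-bromophenyl to 4-chlorophenyl gives a 1.5-fold higher number from compound 1 to compound 4 (0.18 log units; within the scatter), so bromo and chloro cannot be told apart at this position. Among the compounds shown here, this is the first measured step at this position, since the earlier single step altered a different place. No other measurement bears on this result.

Compound 3 carries fluoro here but also differs elsewhere, so it does not isolate that halogen. From the compounds shown here alone, whether a non-halogen group here, such as an amine or a carboxylic acid, would produce a step beyond the scatter remains open.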